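This account rests on a few compounds, and the source may have more. Where it says the series, first, only, none or still open, it means among the compounds named here.

Compound 1, `COC(=O)c1sc2cc(C#Cc3ccc(N)cc3)cnc2c1N`: 2600 nM
Compound 2, `COC(=O)c1sc2cc(C#Cc3ccccc3OC)cnc2c1N`: > 47300 nM

Within the data shown here, in a functional assay on MCF7 cells (Homo sapiens) for inhibition, read by sulforhodamine B assay, with a stated time of 48 h (a lower number here means a stronger inhibitor of growth, a higher number a weaker inhibitor of growth), compound 1 is the only compound that gives a number at all, 2600 nM. For compound 2 the result is a limit of the assay, > 47300 nM, not a number (the limit of > 47300 nM in this assay, at which 1 of the 2 values shown sits). Among the measured compounds shown here, the one measured step, an at least 18-fold higher number from compound 1 to compound 2 (1.25 log units; beyond the scatter), comes from a 2-methoxyphenyl in place of a 4-aminophenyl on the triple-bonded carbon, and it was large.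

Compound 3, `COC(=O)c1sc2cc(C#Cc3cccc(OC)c3)cnc2c1N`, differs from compound 1 as follows: 3-methoxyphenyl in place of 4-aminophenyl on a triple-bonded carbon. For the measured compounds named here, the single measured step bears on this change, since it also exchanges the 4-aminophenyl for a methoxyphenyl, but the methoxy group sits differently in compound 3 than in compound 2, so that step can only be a rough guide. A higher number than for compound 1 in this assay is nevertheless expected, and the step is estimated as a 4.6-fold higher number from compound 1 to compound 3 (0.66 log units; beyond the scatter). The estimate for compound 3 in this assay is therefore 12000 nM, with a range from 3000 nM to 47300 nM, and a real chance that only a limit is reported.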

Compound 3, concentration for 50% growth inhibition: 33400 nM
Beside the measured number, compound 3's estimate is 2.8-fold (0.44 log units) below it; low and high end bracket the measured number.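

In this assay, 3-methoxyphenyl in place of 4-aminophenyl on the triple-bonded carbon gives a 13-fold higher number from compound 1 to compound 3 (1.11 log units; beyond the scatter), so the cost of losing the 4-aminophenyl can now be sized by a measured value rather than only by a limit. The two methoxyphenyl groups are not separated by these data: the step is an at least 1.4-fold lower number from compound 2 to compound 3 (0.15 log units; that floor lies within the scatter), and a floor of that size supports no order between them. Compound 2 remains a limit of the assay and not a number: the limit of > 47300 nM in this assay, at which 1 of the 3 values shown sits.

So far, both replacements of the 4-aminophenyl group carry a methoxy group and both give a much weaker reading, but compound 1 is the only compound shown with an amine, so the change in group and the change in its place on the ring cannot be told apart. A 3-aminophenyl or a 4-methoxyphenyl on the triple-bonded carbon would separate the two, and a plain phenyl would show whether the reading of compound 1 depends on having any such group on the ring at all.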